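Nitro Substitution on the Benzoate of Compound 1

This account rests on a few compounds, and the source may have more. Where it says the series, first, only, none or still open, it means among the compounds named here.

Measured compounds:
- compound 1, `CC1=CC[C@H](C(C)C)c2cc(C)c(OC(=O)c3ccccc3)cc21`: "not active" (no number reported)
- compound 2, `COc1ccc(C(=O)Oc2cc3c(C)ccc(C(C)C)c3cc2C)cc1`: 88.6%

In a functional assay on K562 cells (Homo sapiens) for antiproliferative activity, read by sulforhodamine B assay, with a stated time of 48 h, tested at 50 uM (on this read-out lower numbers stand for less inhibition and higher numbers for more inhibition at the one concentration tested (going by the name of the read-out)), compound 1 is reported as "not active" (no number reported), with no number given, while compound 2 gives 88.6%. Among the compounds with values here, compound 1 therefore has only its reported verdict and no number of its own, and compound 2 carries a different core, so no step between them is computed. Compound 3, `CC1=CC[C@H](C(C)C)c2cc(C)c(OC(=O)c3cccc([N+](=O)[O-])c3)cc21`, differs from compound 1 by nitro in place of hydrogen on an aromatic carbon. In this assay a step from compound 1 toward more inhibition, beyond the scatter, is expected, though its size is uncertain. For compound 3 in this assay the estimate is 35%, within 5% to 75%.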

Compound 3, a percentage reported as inhibition, at one concentration (the size of the read-out at that concentration, not a potency): 15.9%
Beside the measured number, compound 3's estimate is 19.1 percentage points above it, and the stated range covers the measured number.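

In this assay, within the data shown here, compound 1 is reported as "not active" (no number reported) and compound 3 gives 15.9%, so no step between them can be read. The compounds shown leave open how far the change from phenyl to 3-nitrophenyl moves inhibition. Nothing measured here offers an explanation of the result.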